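A few compounds are considered here, and "the series" means these few. Any claim that something is new, unique, unknown or untested is made for them only; others in the source may bear on it.

Series notes, measured in a functional assay on MGC-803 cells (Homo sapiens) for antiproliferative activity, read by MTT assay, with a stated time of 48 h (on this read-out higher numbers stand for weaker inhibition and lower numbers for stronger inhibition), so far:
- compound 1 `COc1ccc(CN(C(=O)CSc2nc3ccccc3s2)c2cc(OC)c(OC)c(OC)c2)cc1N=[N+]=[N-]` gives 187 nM
- compound 2 `COc1ccc(CN(C(=O)CSc2nc3ccccc3s2)c2cc(OC)c(OC)c(OC)c2)cc1` gives 163 nM
- compound 3 `COc1ccc(CN(C(=O)CSc2nc3ccccc3s2)c2cc(OC)c(OC)c(OC)c2)cc1O` has no measurement yet

Compound 2 at 163 nM sits within the scatter of compound 1 at 187 nM and the two numbers set no order. The step under review leads to compound 3, with hydroxy in place of hydrogen on an aromatic carbon as the counted change, hydroxy in place of hydrogen on an aromatic carbon, ortho to a methoxy group.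

Within the data shown here, one measured step bears on it. This is a 1.1-fold lower number from compound 1 to compound 2 (0.06 log units; within the scatter) for hydrogen in place of azido on an aromatic carbon, and it stays small. Among the measured compounds shown here, no measured compound carries a hydroxy group, so this single step is thin support and the direction remains open. In this assay no change beyond the scatter is therefore expected, although the range is kept wide on both sides. The estimated move is a 1.4-fold lower number from compound 2 to compound 3 (0.13 log units; within the scatter) and no more than that is expected. Compound 3 is expected at about 120 nM in this estimate, with a likely range from 40 nM to 320 nM before any measurement.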

Compound 3, half-maximal inhibitory concentration: 35 nM
Estimate against measurement, compound 3: 3.4-fold (0.54 log units) above, outside the stated range (below it).
By their numbers in this assay, from the lowest: compound 3; then compounds 2 and 1 (each within the scatter of the next).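

In this assay, hydroxy on this aromatic carbon, ortho to a methoxy group, brings a clear gain in inhibition, with a 4.7-fold lower number from compound 2 to compound 3 (0.67 log units; beyond the scatter), so this position is not indifferent to its substituent, which the pair of compound 1 and compound 2 alone, within the scatter of each other, did not reveal. Hydroxy also stands apart from the azido group, with a 5.3-fold lower number from compound 1 to compound 3 (0.73 log units; beyond the scatter), and compound 3 is the most potent of the three, so at this position the separation so far belongs to hydroxy alone rather than to the presence of any added group. No measurement at hand accounts for the difference between hydroxy and the other two substituents.

On these data alone, whether an amino group, a fluorine atom or a second methoxy group on the same carbon would match hydroxy remains open, as does whether capping the hydroxy as an ethoxy or acetoxy group would keep the gain. As far as these compounds go, the effect also rests on the shared core of these three compounds alone, and whether it carries over when other parts of that core change is still unknown.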